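The compounds below may be only part of what the source reports. "The series", "measured", "known", "first", "only" and "open" are said of these compounds alone.

Compound 2 `Clc1ccc(-c2cc(-c3cccs3)nc(-c3ccccc3Cl)c2)o1` gives 6190 nM in a functional assay on HCT-15 cells (Homo sapiens) for cytotoxicity, in the presence of a further agent that is not named here (on this read-out higher numbers stand for weaker inhibition and lower numbers for stronger inhibition), the highest of the two numbers recorded; the nearest is compound 1 `Clc1ccc(-c2cc(-c3ccsc3)nc(-c3ccccc3Cl)c2)o1`, which gives 4570 nM, and the step of a 1.4-fold higher number from compound 1 to compound 2 (0.13 log units; within the scatter) lies within the scatter. Compound 3 `Clc1ccc(-c2cc(-c3cccnc3)nc(-c3ccsc3)c2)o1` reaches only a limit of this assay, > 50000 nM, as recorded in the limit of > 50000 nM in this assay, at which 1 of the 3 values shown sits. Compound 4 `Clc1ccc(-c2cc(-c3ccc(Cl)o3)cc(-c3cccs3)n2)cc1` differs from compound 2 by 4-chlorophenyl in place of 2-chlorophenyl on an aromatic carbon. The measured step bearing on that position is an at least 10-fold higher number from compound 1 to compound 3 (1.03 log units; beyond the scatter), a large loss when 2-chlorophenyl was replaced outright; the step of a 1.4-fold higher number from compound 1 to compound 2 (0.13 log units; within the scatter) elsewhere changed little. Compound 4 keeps a chlorophenyl group, so a moderate upward shift is expected in this assay, a 1.9-fold higher number from compound 2 to compound 4 (0.29 log units; within the scatter). Compound 4 is therefore estimated at 12000 nM, within 4000 nM to 45000 nM.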

Compound 4, half-maximal inhibitory concentration: 14200 nM
For compound 4 the middle estimate is 1.2-fold (0.07 log units) below the measured one; low and high end bracket the measured number.
By their numbers in this assay, from the lowest: compounds 1 and 2 (each within the scatter of the next); then compound 4. At a limit, above all of these: compound 3.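

Swapping 2-chlorophenyl for 4-chlorophenyl, with the same atoms, already registers at this position in this assay: a 2.3-fold higher number from compound 2 to compound 4 (0.36 log units; beyond the scatter). The earlier compounds shown here showed only an outright replacement of 2-chlorophenyl, an at least 10-fold higher number from compound 1 to compound 3 (1.03 log units; beyond the scatter), whereas compound 4 still gives a measured number. Compound 3 remains a limit and not a number: the limit of > 50000 nM in this assay, at which 1 of the 4 values shown sits.

Open, as far as these compounds go, is whether a 3-chlorophenyl group, or a phenyl carrying an amine or a carboxylic acid in place of the chlorine, would follow the same direction. Also open, from the compounds shown here alone, is whether the shift holds with the thiophen-3-yl group of compound 1.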